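Halogen swap on the aryl ether of compound 1

This account rests on a few compounds, and the source may have more. Where it says the series, first, only, none or still open, it means among the compounds named here.

Values in a functional assay on A549 cells (Homo sapiens) for antiproliferative activity, read by MTT assay, with a stated time of 72 h (on this read-out lower numbers stand for stronger inhibition and higher numbers for weaker inhibition), for the measured compounds:
- compound 1 `NC1=NC2(CCSCC2)N(OCCCOc2cccc(Cl)c2)C(N)=N1` (60 nM)
- compound 2 `NC1=NC2(CCOCC2)N(OCCCOc2ccc(Cl)cc2Cl)C(N)=N1` (70 nM)
- compound 3 `NC1=NC2(CCOCC2)N(OCCCOc2cc(Cl)c(Cl)cc2Cl)C(N)=N1` (680 nM)

Compound 1 and compound 2 stand within the scatter of each other at the low end of these numbers, and compound 3 lies beyond the scatter of both.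

Compound 4 `NC1=NC2(CCSCC2)N(OCCCOc2ccccc2Br)C(N)=N1` keeps the core of compound 1 and changes only the aryl group: 2-bromophenyl in place of 3-chlorophenyl on an oxygen on a saturated carbon.

Going by the values given here, only one measured step bears on this, and only indirectly. The step of a 9.7-fold higher number from compound 2 to compound 3 (0.99 log units; beyond the scatter), on a different core, shows that chloro in place of hydrogen on an aromatic carbon can raise the number by a modest amount. That step adds a halogen, whereas the present change exchanges one halogen for another. Among the compounds with values here, no measured pair makes such an exchange, and none varies the aryl group on the core of compound 1. A shift beyond the scatter is therefore not expected in this assay, although a modest rise remains possible. The estimated step is a 1.7-fold higher number from compound 1 to compound 4 (0.22 log units; within the scatter) and any movement is expected to be upward. Compound 4 is expected at 100 nM in a range from 30 nM to 350 nM.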

Compound 4, half-maximal inhibitory concentration: 40 nM
The estimate for compound 4 lay 2.5-fold (0.40 log units) above the measured number, and the stated range covers the measured number.
By their numbers in this assay, from the lowest: compounds 4, 1 and 2 (each within the scatter of the next); then compound 3.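

On the core of compound 1, in this assay, 2-bromophenyl in place of 3-chlorophenyl on an oxygen on a saturated carbon gives a 1.5-fold lower number from compound 1 to compound 4 (0.18 log units; within the scatter). Going by these compounds alone, this is the only measured step that varies the aryl group on this core, and it shows that one halogen-bearing phenyl can replace another here with the number staying within the scatter. It also differs in kind from a 9.7-fold higher number from compound 2 to compound 3 (0.99 log units; beyond the scatter), a step on a different core that adds a chloro group to an aromatic carbon rather than exchanging one halogen-bearing aryl group for another, and no measurement shown gives a reason for the result of the exchange on the core of compound 1.

Compound 4 changes both the halogen and its place on the ring, so the compounds shown do not separate these two changes, and 2-chlorophenyl and 3-bromophenyl on the same core would be the pair that does. Also open, as far as these compounds go, is how this core responds to unsubstituted phenyl, to an amine or a carboxylic acid on the aryl ring, or to a longer chain leading to the aryl ether.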